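From fluoro to dimethylamino in a growth inhibitor

A few compounds are considered here, and "the series" means these few. Any claim that something is new, unique, unknown or untested is made for them only; others in the source may bear on it.

Measured so far in a functional assay on Gurav cells (Homo sapiens) for inhibition, read by sulforhodamine B assay (a higher number here means a weaker inhibitor of growth, a lower number a stronger inhibitor of growth), of this series
Compound 1 `Cc1ccc2[nH]c(-c3ccc(-c4ccc(-c5cccc(Cl)c5)cc4)cc3)nc2c1` gives 2120 nM
Compound 2 `COc1ccc(-c2ccc(-c3ccc(-c4nc5cc(C)ccc5[nH]4)cc3)cc2)cc1OC` gives 1310 nM
Compound 3 `Fc1ccc(-c2ccc(-c3ccc(-c4nc5ccccc5[nH]4)cc3)cc2)cc1` gives 100000 nM

Compound 3 has the highest number of the three, which makes it the weakest growth inhibitor here, and its gap to each of the others lies beyond the scatter. Compound 4 `CN(C)c1ccc(-c2ccc(-c3ccc(-c4nc5ccccc5[nH]4)cc3)cc2)cc1` is still unmeasured. It differs from compound 3 in one place, with dimethylamino in place of fluoro on an aromatic carbon, para to a large group dimethylamino in place of fluoro on an aromatic carbon in the new structure. For the measured compounds named here, only one measured step swaps a single group in this way, a 1.6-fold lower number from compound 1 to compound 2 (0.21 log units; within the scatter), and it stays within the scatter. That step starts from a different compound, so it offers only a loose guide. Since compound 1 (2120 nM) and compound 2 (1310 nM) both lie far below compound 3, a move towards a lower number is expected in this assay, though nothing measured shows that this swap closes the whole gap. The expected change is a 13-fold lower number from compound 3 to compound 4 (1.10 log units; beyond the scatter), an estimate with wide uncertainty. For compound 4 the estimated value is 8000 nM, with an expected range from 1000 nM to 100000 nM in this measurement.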

Compound 4, concentration for 50% growth inhibition: 100000 nM
Estimate against measurement, compound 4: 13-fold (1.10 log units) below; measured number inside the range.
By their numbers in this assay, from the lowest: compounds 2 and 1 (each within the scatter of the next); then compounds 3 and 4 (each within the scatter of the next).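

In this assay, putting dimethylamino in place of fluoro on this aromatic carbon, para to a large group, gives no change at the digits printed from compound 3 to compound 4 (within the scatter). So the entering group, with more heavy atoms than the lone fluorine and a hydrogen-bond acceptor that fluoro is not counted as having, leaves the number where it was, and this swap does not bring the compound closer to the values of the two methyl-bearing compounds. Nothing available gives a reason for this result.

On these data alone, whether a carboxylic acid or a hydroxyl group at this same place would shift the number remains open. Also open, as far as these compounds go, is what a methyl group on the core of compound 3 or compound 4 would do on its own.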